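One Group Exchanged, Its Result Still Unknown

The source may report more compounds than this note shows. Statements on the series, on what has been measured and on what is new or still open speak of the compounds shown alone.

In an ADME assay on cells (Peritoneal macrophage cell, Mus musculus) for cytotoxicity, read by fluorescence and resazurin assay, with a stated time of 3 days (on this read-out higher numbers stand for lower toxicity in this test and lower numbers for higher toxicity in this test), compound 1 (`O=C(Nc1cc(-c2ccccn2)n[nH]1)N1CCC(c2cccc(F)c2)CC1`) gives > 45000 nM as a limit, not a number. Compound 2 (`COc1ccccc1C(=O)Nc1[nH]nc(-c2ccccn2)c1C1CC1`) gives > 51000 nM as a limit too. Compound 3 (`O=C(NCc1cccc(Cl)c1)Nc1cc(-c2ccccn2)n[nH]1`) gives > 64000 nM as a limit as well. Compound 1 therefore stands among three limits, with no exact value shown for any compound. Compound 4 (`O=C(Nc1cc(-c2ccccn2)n[nH]1)N1CCC(Oc2ccccn2)CC1`) carries (pyridin-2-yl)oxy in place of 3-fluorophenyl on a saturated ring carbon and keeps the rest of compound 1. No large step is expected in this assay since compound 1 shows > 45000 nM as a limit. The expected change is small, with a step that the limit leaves unreadable from compound 1 to compound 4 as the estimate. Compound 4 is estimated at 60000 nM within a range from 30000 nM to 100000 nM in this test.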

Compound 4, half-maximal cytotoxic concentration: > 64000 nM
Compound 4 gave a limit, no number (the forecaster's own chance of this, stated with the estimate: 75%); at least 1.0-fold (0.02 log units) between middle value and limit.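

Going by these compounds alone, compound 1 and compound 4 each give a limit rather than a number in this assay, and no step between them can be read. The compounds shown leave open at what concentration any of them becomes toxic to these cells.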